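A few compounds are considered here, and "the series" means these few. Any claim that something is new, unique, unknown or untested is made for them only; others in the source may bear on it.

In an ADME assay for permeability, using PAMPA, at pH 7.4 (a higher number here means that the compound crosses the layer faster, a lower number that the compound crosses the layer more slowly), three of the four compounds have a recorded result. Compound 1 `O=C(Nc1cc(-c2nc3ccccc3s2)ccc1Cl)c1cc([N+](=O)[O-])ccc1Cl` carries a chloro group on the ring that bears the amide nitrogen. For compound 1 the entry reads "below limit of detection" (no number reported), and no number is given. Compound 2 `Cc1ccc(-c2nc3ccccc3s2)cc1NC(=O)c1cc([N+](=O)[O-])c(N2CCCCC2)cc1Cl` carries a methyl on that ring and a piperidine on the other ring. In this assay compound 2 gives < 1 10^-6 cm/s, which is a limit of the assay rather than a measured number. Compound 2 therefore sits at the limit of < 1 10^-6 cm/s in this assay, at which 1 of the 3 values shown sits. Among the compounds with values here, compound 3 `O=C(Nc1cc(-c2nc3ccccc3s2)ccc1F)c1cc([N+](=O)[O-])ccc1Cl` carries a fluoro on the ring that bears the amide nitrogen, and in this assay compound 3 gives 191 10^-6 cm/s, the only value in the set that is an actual number.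

Compound 4 `Cc1ccc(-c2nc3ccccc3s2)cc1NC(=O)c1cc([N+](=O)[O-])ccc1Cl` differs from compound 3 in a single place: methyl in place of fluoro on an aromatic carbon. Within the data shown here, no two measured compounds differ from each other by this exchange, so there is no measured step to lean on, and the expectation rests on the change alone. Since one small group replaces another small group, no shift beyond the usual scatter is expected, and the step of a 1.1-fold lower number from compound 3 to compound 4 (0.05 log units; within the scatter) is estimated to stay within it. Compound 4 is expected to give about 170 10^-6 cm/s in this assay, with a range from 80 10^-6 cm/s to 350 10^-6 cm/s.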

Compound 4, apparent permeability: 41 10^-6 cm/s
Compound 4: middle estimate off by 4.1-fold (0.62 log units), on the high side; the whole stated range lies above it.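

In this assay, the aromatic carbon para to a 1,3-benzothiazol-2-yl group proves sensitive to which small group it carries: methyl in place of fluoro goes with a 4.7-fold lower number from compound 3 to compound 4 (0.67 log units; beyond the scatter), even though each group counts one heavy atom and neither brings a hydrogen-bond donor or acceptor. Within the data shown here, the result also gives a first reading of a second place in the molecule, on the other ring, where hydrogen in place of piperidin-1-yl on an aromatic carbon goes with an at least 41-fold higher number from compound 2 to compound 4 (1.61 log units; beyond the scatter). The result for compound 2 that anchors this second step is a limit of the assay and not a number: the limit of < 1 10^-6 cm/s in this assay, at which 1 of the 4 values shown sits.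

Steps to compound 1 cannot be read, as its entry holds no number, so the chloro group cannot yet be placed alongside fluoro and methyl at this position. The compounds shown leave open how this position responds to other groups, such as a methoxy group or a nitrile, and how the ring that bore the piperidin-1-yl group responds to a smaller amine such as dimethylamino.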